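Aromatic nitro group swapped in for a small ring

A few compounds are considered here, and "the series" means these few. Any claim that something is new, unique, unknown or untested is made for them only; others in the source may bear on it.

Compound 1 `CCN(Cc1c(C(F)(F)F)nc2n(-c3c(C)cc(C)cc3C)c(Cl)cn12)CC1CC1`: 9 nM
Compound 2 `CCCN(Cc1c(C(F)(F)F)nc2n(-c3c(C)cc(C)cc3C)c(Cl)cn12)CC1CCC1`: 5.3 nM

Both numbers come from an assay on cells for displacement of a labelled ligand from corticotropin-releasing factor receptor 1 (Homo sapiens), with a stated time of 100 min; a lower number here means a stronger inhibitor, a higher number a weaker inhibitor. Compound 2 and compound 1 sit within the usual scatter of each other, so neither can be called the stronger. Compound 3 `CCCN(Cc1ccc([N+](=O)[O-])cc1)Cc1c(C(F)(F)F)nc2n(-c3c(C)cc(C)cc3C)c(Cl)cn12` is not yet measured; it differs from compound 2 by 4-nitrophenyl in place of cyclobutyl on a saturated chain carbon bound to an amine nitrogen. Among the measured compounds shown here, the only measured step, a 1.7-fold lower number from compound 1 to compound 2 (0.23 log units; within the scatter), altered both groups on the amine nitrogen and left the number essentially unchanged, which suggests changes at this position can be tolerated, but says nothing about an aromatic ring bearing a nitro group. For compound 3 the estimate is 15 nM, with an expected range from 4 nM to 60 nM. The expected step is a 2.8-fold higher number from compound 2 to compound 3 (0.45 log units; beyond the scatter).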

Compound 3, inhibition constant: 150 nM
Estimate against measurement, compound 3: 10-fold (1.00 log units) below, outside the stated range (above it).
By their numbers in this assay, from the lowest: compounds 2 and 1 (each within the scatter of the next); then compound 3.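

Unlike the earlier change on this amine nitrogen, which stayed within the scatter, putting 4-nitrophenyl in place of cyclobutyl gives a 28-fold higher number from compound 2 to compound 3 (1.45 log units; beyond the scatter) and so shows that this position does not accept every group. Tolerance here therefore has a limit, which compound 1 and compound 2 alone could not reveal. No measurement shown explains the loss. A plain benzyl group, without the nitro group, would help separate the contribution of the ring from that of the nitro group. Going by these compounds, whether a longer open chain, such as hexyl, is accepted also remains open.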